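A few compounds are considered here, and "the series" means these few. Any claim that something is new, unique, unknown or untested is made for them only; others in the source may bear on it.

In an ADME assay on microsomes from liver (Homo sapiens) for metabolic stability, read by LC-MS, using NADPH, with a stated time of 30 min, tested at 1 uM (on this read-out higher numbers stand for fast clearance and lower numbers for slow clearance), compound 1 `CC(C)c1noc(N2CCC(Oc3cc(N4CCc5cc(N6CC(O)CCC6=O)ccc54)ncn3)CC2)n1` gives 1 mL.min-1.g-1 and compound 2 `CC(=O)N(C)c1ccc2c(c1)CCN2c1cc(OC2CCN(c3nc(C(C)C)no3)CC2)ncn1` gives 173 mL.min-1.g-1, while compound 3 `CC(C)c1noc(N2CCC(Oc3cc(N4CCc5cc(S(C)(=O)=O)ccc54)ncn3)CC2)n1` gives 69 mL.min-1.g-1 as the second highest of the three numbers. Compound 4 `CC(C)c1noc(N2CCC(Oc3cc(N4CCc5cc(N6CCC(O)CC6=O)ccc54)ncn3)CC2)n1` is still unmeasured and carries 4-hydroxy-2-oxopiperidin-1-yl in place of methylsulfonyl on an aromatic carbon of compound 3 (4-hydroxy-2-oxopiperidin-1-yl in place of methylsulfonyl on an aromatic carbon). The closest evidence is the large step (a 69-fold higher number from compound 1 to compound 3 (1.84 log units; beyond the scatter)) in which methylsulfonyl replaced 5-hydroxy-2-oxopiperidin-1-yl, a group whose name differs from the entering one only in its number. The large step (a 170-fold higher number from compound 1 to compound 2 (2.24 log units; beyond the scatter)) with acetyl(methyl)amino agrees, whereas the modest step (a 2.5-fold lower number from compound 2 to compound 3 (0.40 log units; beyond the scatter)) says nothing about the entering group. Going by the values given here, a large step to a lower number is therefore expected (a 17-fold lower number from compound 3 to compound 4 (1.24 log units; beyond the scatter)), although no measured compound carries the entering group itself. For compound 4 the estimated value is 4 mL.min-1.g-1 (expected range 1 mL.min-1.g-1 to 20 mL.min-1.g-1).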

Compound 4, intrinsic clearance in microsomes in the Homo sapiens assay: 4 mL.min-1.g-1
Compound 4: middle estimate and measured number agree at the digits printed; the range from low to high includes it.
By their numbers in the Homo sapiens assay, from the lowest: compound 1; then compound 4; then compound 3; then compound 2.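

In the Homo sapiens assay the low number of compound 1 1 mL.min-1.g-1 does not depend on one exact hydroxy placement, since compound 4 with 4-hydroxy-2-oxopiperidin-1-yl also gives a low number 4 mL.min-1.g-1 and large drops, with a 17-fold lower number from compound 3 to compound 4 (1.24 log units; beyond the scatter) and a 43-fold lower number from compound 2 to compound 4 (1.64 log units; beyond the scatter). Moving between the two hydroxy-2-oxopiperidin-1-yl groups still counts, however, with a 4.0-fold higher number from compound 1 to compound 4 (0.60 log units; beyond the scatter). In a physicochemical assay for lipophilicity, measured as octanol-water partition, at pH 7.4 (a lower number here means a more polar compound, a higher number a more lipophilic compound), compound 3 gives 3.1 and compound 4 gives 2.8; the same change gives a number 0.30 log units lower from compound 3 to compound 4 (within the scatter), and nothing available explains the differences in clearance. Among the compounds shown, none carries an unsubstituted 2-oxopiperidin-1-yl group at this aromatic carbon, so the share of the hydroxy itself remains open. On these data alone, a carboxylic acid or an amine at this place also remains untested here.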